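The source may report more compounds than this note shows. Statements on the series, on what has been measured and on what is new or still open speak of the compounds shown alone.

Working notes on the dichloroacetamide series.

Compound 1 `Cc1ccccc1-c1cccc(NC(=O)C(Cl)Cl)c1` gives 9860 nM in a functional assay on A549 cells (Homo sapiens) for cytotoxicity, read by MTT assay, with a stated time of 68 h; a lower number here means a stronger inhibitor, a higher number a weaker inhibitor. Compound 2 `O=C(Nc1cccc(-c2ccccc2F)c1)C(Cl)Cl` gives 13200 nM in this assay. The step of a 1.3-fold higher number from compound 1 to compound 2 (0.13 log units; within the scatter) corresponds to the change (fluoro in place of methyl on an aromatic carbon).

Compound 3 `Cc1ccc(-c2cccc(NC(=O)C(Cl)Cl)c2)cc1` gives 8300 nM in this assay. The difference between the core of compound 3 and the core of compound 1 is not broken down here; the two values lie within the scatter of each other, so no ordering is drawn. The values of compound 3 and compound 2 likewise lie within the scatter of each other.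

Compound 4 `O=C(Nc1cccc(-c2ccc(F)cc2)c1)C(Cl)Cl` is not yet measured. It differs from compound 3 by fluoro in place of methyl on an aromatic carbon. This is the same kind of change as that from compound 1 to compound 2, not the same: there the group sits ortho to a large group, here para to a large group.

For compound 4 the step of a 1.3-fold higher number from compound 3 to compound 4 (0.12 log units; within the scatter) is expected in this assay, resting on the step of a 1.3-fold higher number from compound 1 to compound 2 (0.13 log units; within the scatter) being within the scatter. Compound 4 is thus estimated at 11000 nM, between 6000 nM and 20000 nM.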

Compound 4, half-maximal inhibitory concentration: 7840 nM
Beside the measured number, compound 4's estimate is 1.4-fold (0.15 log units) above it; measured number inside the range.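

Fluoro in place of methyl on an aromatic carbon, para to a large group, gives a 1.1-fold lower number from compound 3 to compound 4 (0.02 log units; within the scatter) in this assay. Set beside the same change on the core of compound 1, this step does not differ from the earlier one: the same change on two cores in this assay, a 1.3-fold higher number (0.13 log units; within the scatter) from compound 1 to compound 2 and a 1.1-fold lower number (0.02 log units; within the scatter) from compound 3 to compound 4, 1.4-fold (0.15 log units) apart, within the scatter of two such steps. Within these two pairs the change carries from one core to the other without a readable difference, but neither step is beyond the scatter, so this shows no effect of the change on either core, and with only two pairs, in which the place of the group also differs, it sets no rule for the series.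

The compounds shown carry only methyl or fluoro on the ring, so it remains open whether an amine, a carboxylic acid or a methoxy group in the same place would give a step beyond the scatter. From the compounds shown here alone, it also remains open whether such a step would carry from one core to the other.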